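Aryl ester variation on a shared bicyclic core

The source may hold more compounds than are shown below. What is called first, only, known or untested is meant among the compounds shown, and "the series" means these compounds.

Measured so far:
- compound 1 `COc1cccc(C(=O)Oc2cc3c(cc2C)[C@@H](C(C)C)CC=C3C)c1` — 24.2%
- compound 2 `CC1=CC[C@H](C(C)C)c2cc(C)c(OC(=O)c3cccc(C)c3)cc21` — "not active" (no number reported)
- compound 3 `CC1=CC[C@H](C(C)C)c2cc(C)c(OC(=O)c3ccc(Cl)cc3)cc21` — 17.4%

All three share one core and differ only in the aryl group on the ester carbonyl. In a functional assay on SK-LU-1 cells (Homo sapiens) for antiproliferative activity, read by sulforhodamine B assay, with a stated time of 48 h, tested at 50 uM (a higher number here means more inhibition at the concentration tested (going by the name of the read-out), a lower number less inhibition), compound 1 gives 24.2%, and compound 3 gives 17.4%; the step of a number 6.8 percentage points lower from compound 1 to compound 3 (within the scatter) does not rise above the scatter. Compound 2 stands apart: in this assay compound 2 is recorded as "not active" (no number reported), so no number places it against the other two.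

The next compound, compound 4 `CC1=CC[C@H](C(C)C)c2cc(C)c(OC(=O)c3cccc(C(F)(F)F)c3)cc21`, changes the substituent on the aryl ring of compound 2: trifluoromethyl in place of methyl on an aromatic carbon. Within the data shown here, no measured step follows this exact change. Among the measured compounds shown here, the only step available, between compound 1 and compound 3, swaps one aryl substituent for another and stays within the scatter, which suggests that substituent changes on this ring move this assay little. Compound 2 has no number to start from, so the two numbered compounds set the likely range. For compound 4 in this assay a read-out of 15% is estimated, spanning 0% to 32%, with a fair chance that it is again reported only as not active.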

Compound 4, a percentage reported as inhibition, at one concentration (the size of the read-out at that concentration, not a potency): 18.3%
For compound 4 the middle estimate is 3.3 percentage points below the measured one, and the stated range covers the measured number.
By their numbers in this assay, from the lowest: compounds 3, 4 and 1 (each within the scatter of the next).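

In this assay compound 4 gives 18.3% while compound 2, with methyl at the same place, is recorded as "not active" (no number reported) and the step between them cannot be read. Trifluoromethyl in place of methoxy gives a number 5.9 percentage points lower from compound 1 to compound 4 (within the scatter) and so does not separate these two groups at this place in the read-out. The data shown give no reason for these readings.

The compounds shown leave open whether an amine or a carboxylic acid on this aryl ring would carry the read-out beyond the scatter. Also open, on these data alone, is whether a longer chain in place of trifluoromethyl, or an amide in place of the ester, would give a reading apart from the three numbers now in hand.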